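The source may hold more compounds than are shown below. What is called first, only, known or untested is meant among the compounds shown, and "the series" means these compounds.

Measured so far:
- Compound 1 `CCCCCCCCCCNC(=O)c1c[nH]c(-c2ccccc2)n1`: > 30000 nM, a limit of the assay, not a number
- Compound 2 `CCCCCCCCCCCCCCNC(=O)c1c[nH]c(-c2ccccc2)n1`: 18700 nM

Going by the values given here, in a functional assay on A-375 cells (Homo sapiens) for antiproliferative activity, read by sulforhodamine B assay, with a stated time of 48 h (on this read-out lower numbers stand for stronger inhibition and higher numbers for weaker inhibition), compound 2 gives the only actual number, 18700 nM. Compound 3 `CCCCCCCCCCCCCCCCCCNC(=O)c1c[nH]c(-c2ccccc2)n1` differs from compound 2 by butyl in place of hydrogen on a saturated chain carbon, ten or more bonds along the chain from an amide-type nitrogen. Among the compounds with values here, the one measured step bearing on this is the same change: an at least 1.6-fold lower number from compound 1 to compound 2 (0.20 log units; that floor lies within the scatter). On that single step, only a small move toward a lower number is expected in this assay, not clearly beyond the scatter: expected a 1.2-fold lower number from compound 2 to compound 3 (0.10 log units; within the scatter). For compound 3 the estimated value is 15000 nM, with an expected range of 6000 nM to 32000 nM.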

Compound 3, half-maximal inhibitory concentration: 20700 nM
Compound 3: the middle estimate sits 1.4-fold (0.14 log units) below what was measured; measured number inside the range.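

In this assay, butyl in place of hydrogen on a saturated chain carbon can now be read between two actual numbers, giving a 1.1-fold higher number from compound 2 to compound 3 (0.04 log units; within the scatter). The earlier step of this kind rested on a limit and gave only a floor, whereas this one gives a size and stays within the scatter. The value of compound 1 is also a limit, so an at least 1.4-fold lower number from compound 1 to compound 3 (0.16 log units; that floor lies within the scatter) remains a floor: the limit of > 30000 nM in this assay, at which 1 of the 3 values shown sits. Open, as far as these compounds go, is whether an amine or a carboxylic acid in place of butyl would move the number beyond the scatter.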